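A benzylsulfonyl group replaces a carbonyl side chain

The source may hold more compounds than are shown below. What is called first, only, known or untested is meant among the compounds shown, and "the series" means these compounds.

Compound 1 `COc1cccc(C(=O)Oc2cc(/C=C/C(=O)c3ccc(OC)c4c3OC(C)(C)C=C4)ccc2OC)c1`: > 10000 nM (a limit of the assay)
Compound 2 `COc1ccc(/C=C/C(=O)Oc2cc(/C=C/C(=O)c3ccc(OC)c4c3OC(C)(C)C=C4)ccc2OC)cc1`: 18000 nM

Among the measured compounds shown here, in an ADME assay on L02 cells (Homo sapiens) for cytotoxicity, read by MTT assay (a higher number here means a weaker inhibitor, a lower number a stronger inhibitor), compound 2 gives 18000 nM, the only exact number among the measured compounds. Compound 1 gives > 10000 nM, which is a limit of the assay and not a number.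

Compound 3 `COc1ccc(/C=C/C(=O)c2ccc(OC)c3c2OC(C)(C)C=C3)cc1OS(=O)(=O)Cc1ccccc1` is not yet measured. It keeps the shared core of compound 2 and changes one substituent: benzylsulfonyl in place of (2-(4-methoxyphenyl)ethenyl)carbonyl on an oxygen on an aromatic ring. Benzylsulfonyl stands in place of (2-(4-methoxyphenyl)ethenyl)carbonyl on an oxygen on an aromatic ring.

For the measured compounds named here, only one measured step bears on this place, a step that the limit leaves unreadable from compound 1 to compound 2. From the compounds shown here alone, its size stays unknown because of the limit of > 10000 nM in this assay, at which 1 of the 2 values shown sits. Going by the values given here, the measurements therefore offer no sized precedent for a change here, and they point in neither direction. No shift beyond the scatter is expected in this assay, with a slight fall being the working expectation. The expected step is a 1.2-fold lower number from compound 2 to compound 3 (0.08 log units; within the scatter). For compound 3 the estimated value is 15000 nM. The expected range for compound 3 runs from 6000 nM to 40000 nM.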

Compound 3, half-maximal inhibitory concentration: > 10000 nM
Compound 3: a limit, no number (the forecaster's own chance of this, stated with the estimate: 40%); the middle value is on the limit's open side.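

The steps from compound 2 to compound 3 and from compound 1 to compound 3 cannot be read in this assay, because they rest on a limit of the assay and not on a number: the limit of > 10000 nM in this assay, at which 2 of the 3 values shown sit.

The compounds shown leave open whether benzylsulfonyl in place of (2-(4-methoxyphenyl)ethenyl)carbonyl on an oxygen on an aromatic ring changes the read-out at all, and by how much.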